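The compounds below may be only part of what the source reports. "The series", "measured", "known", "first", "only" and "open" are said of these compounds alone.

In a functional assay on the whole organism with Canis familiaris (Canis lupus familiaris) as the target (a lower number here means that less compound is needed, a higher number that more compound is needed for the effect), compound 1 `Cn1cnc2c(SCC(O)CN3CCN(C(c4ccc(F)cc4)c4ccc(F)cc4)CC3)ncnc21` gives 1.9 mg/kg, compound 2 `OC(CNc1[nH]cnc2ncnc1-2)CN1CCN(C(c2ccc(F)cc2)c2ccc(F)cc2)CC1` gives 0.28 mg/kg and compound 3 `CC(=O)OC(CNc1[nH]cnc2ncnc1-2)CN1CCN(C(c2ccc(F)cc2)c2ccc(F)cc2)CC1` gives 0.27 mg/kg. Compound 2 therefore stands level with compound 3, as a 1.0-fold lower number from compound 2 to compound 3 (0.02 log units; within the scatter) shows, and clearly under compound 1.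

The still unmeasured compound 4 `OC(COc1[nH]cnc2ncnc1-2)CN1CCN(C(c2ccc(F)cc2)c2ccc(F)cc2)CC1` departs from compound 2 in one place: a group of 10 heavy atoms (5 carbon, 4 nitrogen, 1 oxygen; one five-membered aromatic ring with 2 hetero atoms, one six-membered aromatic ring with 2 hetero atoms) in place of a group of 10 heavy atoms (5 carbon, 5 nitrogen; one five-membered aromatic ring with 2 hetero atoms, one six-membered aromatic ring with 2 hetero atoms), on a saturated chain carbon, two bonds along the chain from an oxygen on a saturated carbon. The step that bears most directly on this change is a 6.8-fold lower number from compound 1 to compound 2 (0.83 log units; beyond the scatter), since it also exchanges the group at this place. The acetyl step, a 1.0-fold lower number from compound 2 to compound 3 (0.02 log units; within the scatter), concerns the oxygen on a saturated carbon, which compound 4 keeps as in compound 2, so it offers little guidance. For the measured compounds named here, the data hold no measured compound with the new group, and the estimate rests on this single precedent. A modest rise in the required dose is expected, smaller than the step between compound 1 and compound 2. The expected change is a 2.5-fold higher number from compound 2 to compound 4 (0.40 log units; beyond the scatter). For compound 4 the estimated dose is 0.7 mg/kg, with an expected range of 0.25 mg/kg to 2 mg/kg.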

Compound 4, dose for half-maximal effect: 0.72 mg/kg
Estimate against measurement, compound 4: 1.0-fold (0.01 log units) below, and the stated range covers the measured number.
By their numbers in this assay, from the lowest: compounds 3 and 2 (each within the scatter of the next); then compound 4; then compound 1.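

At this place on a saturated chain carbon, the result shows that this assay responds to an exchange that leaves the heavy-atom count unchanged: the group with 5 carbon, 4 nitrogen and 1 oxygen, which has 1 hydrogen-bond donor rather than 2, gives a 2.6-fold higher number from compound 2 to compound 4 (0.41 log units; beyond the scatter). That same group still compares favourably with the sulfur-bearing group, with a 2.6-fold lower number from compound 1 to compound 4 (0.42 log units; beyond the scatter), so all three groups at this place are separated by steps beyond the scatter. No supporting evidence is available to explain these differences.

The sulfur-bearing group also has one more carbon, so the steps from compound 1 do not separate the effect of sulfur from that of the extra carbon. Still open, as far as these compounds go, are how an acetyl on the oxygen on a saturated carbon would behave alongside the group of compound 4, and how an amine or a longer chain at this place would compare.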